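A Methyl Added to Compound 3: What to Expect

The compounds below may be only part of what the source reports. "The series", "measured", "known", "first", "only" and "open" are said of these compounds alone.

Compound 1 `Cc1ncc([N+](=O)[O-])n1CC(O)CSC(=S)N(C)C` gives only a limit of > 5000000 nM in a toxicity assay on HeLa cells (Homo sapiens) for cytotoxicity, read by MTT assay, with a stated time of 24 h (on this read-out higher numbers stand for weaker inhibition and lower numbers for stronger inhibition), and no number.
Compound 2 `Cc1ncc([N+](=O)[O-])n1CC(O)CN1CCCC1` gives only a limit of > 5000000 nM in this assay and no number.
Compound 3 `Cc1ncc([N+](=O)[O-])n1CC(O)CN1CCCCC1` gives only a limit of > 5000000 nM in this assay and no number.

All three measured compounds share the same core and differ only in the group that sits two bonds along the chain from the oxygen on a saturated carbon. Compound 3 therefore stands at the limit of this assay rather than at a measured number. The same holds for every value shown, since all of them sit at that limit of > 5000000 nM in this assay, at which 3 of the 3 values shown sit, together. For this reason the step that the two limits leave unreadable from compound 1 to compound 2 and the steps a step that the two limits leave unreadable from compound 1 to compound 3 and a step that the two limits leave unreadable from compound 2 to compound 3 cannot be read in either direction.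

Compound 4 `Cc1ncc([N+](=O)[O-])n1CC(O)CN1CCC(C)CC1` differs from compound 3 by methyl in place of hydrogen on a saturated ring carbon only. The measured steps bear on it just in one way: none of them, even the larger ring swaps, moved a value off the limit of > 5000000 nM in this assay, at which 3 of the 3 values shown sit, at all. So no step beyond the scatter is expected, and the step from compound 3 to compound 4 is estimated as a step that the limit leaves unreadable from compound 3 to compound 4 in size. Compound 4 is expected to give about 6000000 nM in this assay and most likely again only as a limit. Its estimated range runs from 2500000 nM to 30000000 nM in the same read-out.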

Compound 4, half-maximal inhibitory concentration: > 5000000 nM
Compound 4 was reported as a limit; the forecaster's own chance of this, stated with the estimate: 85%; the middle value does not contradict the limit.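

Compound 3 and compound 4 are both reported only as limits, so no step can be read for methyl in place of hydrogen on the saturated ring carbon; all the compounds shown share one value: the limit of > 5000000 nM in this assay, at which 4 of the 4 values shown sit. The compounds shown leave open which change, if any, would bring a measured number in this assay.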